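Thiophene Regioisomer of an Inactive Bis-Heteroaryl Pyridine

A few compounds are considered here, and "the series" means these few. Any claim that something is new, unique, unknown or untested is made for them only; others in the source may bear on it.

In a functional assay on MCF7 cells (Homo sapiens) for cytotoxicity, with a stated time of 3 days (a lower number here means a stronger inhibitor, a higher number a weaker inhibitor), compound 2 `Clc1ccc(-c2cc(-c3cccs3)nc(-c3cccs3)c2)o1` gives > 100000 nM, which is a limit of the assay and not a number. Compound 1 `c1csc(-c2cc(-c3ccoc3)cc(-c3cccs3)n2)c1` likewise gives > 100000 nM, again a limit. The step that the two limits leave unreadable from compound 1 to compound 2 stays unreadable, as the limit of > 100000 nM in this assay, at which 2 of the 2 values shown sit, records. Compound 3 `Clc1ccc(-c2cc(-c3ccsc3)nc(-c3cccs3)c2)o1` differs from compound 2 by thiophen-3-yl in place of thiophen-2-yl on an aromatic carbon. Within the data shown here, no measured step bears on this change, and both values shown are limits. The step of a number no higher from compound 2 to compound 3 (the limit leaves the size open) is estimated as no change beyond the scatter. Compound 3 is expected to give 100000 nM, with a range from 40000 nM to 300000 nM.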

Compound 3, half-maximal inhibitory concentration: > 100000 nM
Compound 3: a limit, no number; the forecaster's own chance of this, stated with the estimate: 85%; the middle value sits exactly at the limit.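

Compound 3 gives > 100000 nM, a limit and not a number. No step from compound 2 to compound 3 can be read, since both sit at the same limit: the limit of > 100000 nM in this assay, at which 3 of the 3 values shown sit.

The compounds shown leave open whether thiophen-3-yl and thiophen-2-yl differ at all in cytotoxicity.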